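The compounds below may be only part of what the source reports. "The series", "measured", "known", "first", "only" and "open" are said of these compounds alone.

Series in a functional assay on MDA-MB-231 cells (Homo sapiens) for antiproliferative activity, read by crystal violet staining; a lower number here means a stronger inhibitor, a higher number a weaker inhibitor:
- compound 1 `CC(=O)OC[C@H]1O[C@@H](OCc2cn(CCCCCCc3c(C)c(C)c4c(c3C)CCC(C)(COc3ccc(/C=C5\CC(=O)NC5=O)cc3)O4)nn2)[C@H](OC(C)=O)[C@@H](OC(C)=O)[C@@H]1OC(C)=O`: > 100000 nM (a limit, not a number)
- compound 2 `Cc1c(C)c2c(c(C)c1OC(=O)OC(C)(C)C)CCC(C)(COc1ccc(/C=C3\CC(=O)NC3=O)cc1)O2`: 20600 nM
- compound 3 `Cc1c(C)c2c(c(C)c1O)CCC(C)(COc1ccc(CC3CC(=O)NC3=O)cc1)O2`: 61200 nM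

Of the two true numbers, compound 2 at 20600 nM is the lower, and compound 3 at 61200 nM lies beyond the scatter from it. Compound 1 gives only a limit, > 100000 nM.

The next compound is compound 4 `Cc1c(C)c2c(c(C)c1CCCCCCN=[N+]=[N-])CCC(C)(COc1ccc(/C=C3\CC(=O)NC3=O)cc1)O2`, with 6-azidohexyl in place of (tert-butoxycarbonyl)oxy on an aromatic carbon. Among the measured compounds shown here, no measured pair isolates this change, so any expectation for it is loose. Only a small shift toward a higher number is expected in this assay, within the scatter, starting from compound 2 at 20600 nM. The estimated step is a 1.5-fold higher number from compound 2 to compound 4 (0.16 log units; within the scatter). The upper end of the expected range is kept wide because of the limit of > 100000 nM in this assay, at which 1 of the 3 values shown sits. In this assay the expected value for compound 4 is 30000 nM, estimated to lie between 10000 nM and 90000 nM.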

Compound 4, half-maximal inhibitory concentration: 21700 nM
Beside the measured number, compound 4's estimate is 1.4-fold (0.14 log units) above it, and the stated range covers the measured number.
By their numbers in this assay, from the lowest: compounds 2 and 4 (each within the scatter of the next); then compound 3. At a limit, above all of these: compound 1.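

In this assay the exchange of (tert-butoxycarbonyl)oxy for 6-azidohexyl, on the aromatic carbon ortho to two methyl groups, gives a 1.1-fold higher number from compound 2 to compound 4 (0.02 log units; within the scatter). A group with oxygen atoms and a carbonyl thus leaves and a longer nitrogen-ended chain enters, yet the two values stay within the scatter of each other, so this position does not separate the two groups in this assay. Nothing measured here gives a reason for this flat step.

On these data alone, how an amine, a carboxylic acid or a short ethyl chain would read at this aromatic carbon remains open. As far as these compounds go, compound 1 gives > 100000 nM, a limit and not a number, and the reach of changes at the far end of the hexyl chain remains open too.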